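This account rests on a few compounds, and the source may have more. Where it says the series, first, only, none or still open, it means among the compounds named here.

Measured in a functional assay on cells (Pituitary gland cell) for antagonist activity at Gonadotropin-releasing hormone receptor (Rattus norvegicus); a higher number here means a weaker inhibitor, a lower number a stronger inhibitor:
- compound 1 `O=[N+]([O-])c1cc2c(OCCC3CCCCN3)c(-c3ccccc3)c(O)nc2cc1Cl`: 410 nM
- compound 2 `Cc1cc(-c2c(O)nc3cc(Cl)c([N+](=O)[O-])cc3c2OCCC2CCCCN2)cc(C(C)O)c1`: 63 nM

Compound 1 holds the highest of the two numbers. Among the compounds with values here, the one step so far, a 6.5-fold lower number from compound 1 to compound 2 (0.81 log units; beyond the scatter), shows that a substituted phenyl on the shared core can lower the number beyond the scatter.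

Compound 3 `Cc1ccc(-c2c(O)nc3cc(Cl)c([N+](=O)[O-])cc3c2OCCC2CCCCN2)c(C)c1` is unmeasured. Relative to compound 1 it carries 2,4-dimethylphenyl in place of phenyl on an aromatic carbon. That step bears on it only loosely, since the substitution pattern differs; a smaller change is expected, in the same direction. The estimated step is a 2.1-fold lower number from compound 1 to compound 3 (0.31 log units; beyond the scatter). Compound 3 is expected to give 200 nM, within 60 nM to 700 nM.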

Compound 3, half-maximal inhibitory concentration: 400 nM
Compound 3: the middle estimate sits 2.0-fold (0.30 log units) below what was measured, and the stated range covers the measured number.
By their numbers in this assay, from the lowest: compound 2; then compounds 3 and 1 (each within the scatter of the next).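

In this assay, 2,4-dimethylphenyl in place of phenyl on this aromatic carbon leaves compound 3 level with compound 1 (a 1.0-fold lower number from compound 1 to compound 3 (0.01 log units; within the scatter)), so a substituted phenyl at this position does not by itself lower the number. Replacing 3-(1-hydroxyethyl)-5-methylphenyl with 2,4-dimethylphenyl gives a 6.3-fold higher number from compound 2 to compound 3 (0.80 log units; beyond the scatter), which places the lower number of compound 2 with its own substituent pattern, not with aryl substitution in general. Nothing available explains either step.

The compounds shown leave open whether the 1-hydroxyethyl group or the substitution pattern matters more. A 3-(1-hydroxyethyl)phenyl without the methyl, or an aminomethyl or carboxylic acid in place of the 1-hydroxyethyl, would separate these.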